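The compounds below may be only part of what the source reports. "The series", "measured", "known", "first", "only" and "open" are said of these compounds alone.

Measured so far in an ADME assay on microsomes from liver (Rattus norvegicus) for metabolic stability; a higher number here means that the compound lasts longer, a lower number that the compound disappears faster
- compound 1 `CC(C)C(c1ncco1)c1ccc(-c2ccc3cccc(F)c3c2)[nH]c1=O` gives 0.0983 h
- compound 2 `CC(C)C(c1ccc(-c2ccc3cccc(F)c3c2)[nH]c1=O)N1CCNC1=O` gives 0.283 h

Compound 2 holds the higher of the two numbers. Next in the series is compound 3 `CC(C)C(/C=C1\CCNC1=O)c1ccc(-c2ccc3cccc(F)c3c2)[nH]c1=O` with the change a group of 7 heavy atoms (5 carbon, 1 nitrogen, 1 oxygen; one five-membered non-aromatic ring with 1 hetero atom) in place of a group of 6 heavy atoms (3 carbon, 2 nitrogen, 1 oxygen; one five-membered non-aromatic ring with 2 hetero atoms), on a saturated chain carbon bound to an aromatic carbon and a saturated chain carbon on a saturated chain carbon bound to an aromatic carbon and a saturated chain carbon. Among the measured compounds shown here, only one measured step bears on this. It is a 2.9-fold higher number from compound 1 to compound 2 (0.46 log units; beyond the scatter) and it comes with 2-oxoimidazolidin-1-yl in place of 1,3-oxazol-2-yl on that same carbon. That step shows that a swap at this carbon can shift this assay by a modest amount. For the measured compounds named here, no measured compound carries the entering group, so the direction stays open. A step within the scatter is expected, with a slight lean to a lower number. The expected step is a 1.4-fold lower number from compound 2 to compound 3 (0.15 log units; within the scatter) as an estimate only. Compound 3 is estimated at 0.2 h with an expected range from 0.07 h to 0.5 h in this assay series.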

Compound 3, half-life: 0.345 h
Compound 3: middle estimate off by 1.7-fold (0.24 log units), on the low side, within the range that was stated.
By their numbers in this assay, from the lowest: compound 1; then compounds 2 and 3 (each within the scatter of the next).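

In this assay, the group of compound 3, with one hetero atom in its five-membered non-aromatic ring, in place of 2-oxoimidazolidin-1-yl gives a 1.2-fold higher number from compound 2 to compound 3 (0.09 log units; within the scatter), so this change on the saturated chain carbon does not separate the two non-aromatic ring groups. Set against the 1,3-oxazol-2-yl group, the same entering group gives a 3.5-fold higher number from compound 1 to compound 3 (0.55 log units; beyond the scatter), so among these three compounds both non-aromatic ring groups stand apart from the aromatic ring group of compound 1. No measurement at hand explains this difference.

Going by these compounds, whether an open-chain amide, a simple amine or a carboxylic acid on this carbon would stay level with compound 2 and compound 3 remains open. Also open is what the exocyclic double bond of compound 3 contributes, as the series shown holds no saturated counterpart.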